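The compounds below may be only part of what the source reports. "The series", "measured", "known", "first", "only" and "open" are said of these compounds alone.

Measured so far:
compound 1, `COC(=O)c1c(Nc2ccccc2)sc(C(=O)c2ccc(C)cc2)c1C`, 6.06%;
compound 2, `COC(=O)c1c(Nc2ccc(C)cc2)sc(C(=O)c2ccc(C)cc2)c1C`, "not active" (no number reported).

In a functional assay, with a stated time of 150 min, tested at 20 ug/mL (on this read-out higher numbers stand for a stronger effect at the one concentration tested and lower numbers for a weaker effect), compound 1 gives 6.06%, a weak effect at the one concentration tested. Among the compounds with values here, compound 2 is reported in this assay as "not active" (no number reported), with no number attached, so it stands below compound 1 only in the sense that nothing measurable was recorded for it; the two values show a weak read-out and a blank, and no sized step between them can be stated.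

Compound 3, `COC(=O)c1c(Nc2ccc(F)cc2)sc(C(=O)c2ccc(C)cc2)c1C`, has not been measured. It differs from compound 2 in one place: fluoro in place of methyl on an aromatic carbon. Fluoro in place of methyl on an aromatic carbon, para to a large group, is a small exchange in a part of the molecule where compound 1 and compound 2 together give no sign that much is gained. Within the data shown here, with no step between measured compounds in this assay to draw on, the expectation for compound 3 is a read-out near the bottom of the scale, no further from compound 1 than the scatter, and with a fair chance that only "not active" is reported.

Compound 3 is expected to give about 5% in this assay, within 0% to 15%.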

Compound 3, a percentage reported as activity, at one concentration (the size of the read-out at that concentration, not a potency): "not active" (no number reported)
Compound 3 has no reported number here; there is nothing to compare the estimate with.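

In this assay, within the data shown here, compound 2 reads "not active" (no number reported) and compound 3 reads "not active" (no number reported), so no step from methyl to fluoro can be read between these two compounds. No evidence on hand bears on this result. The compounds shown leave open whether any group at this place gives a read-out that stands clear of compound 1.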